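Working notes: N-sulfonylation of compound 2

This account rests on a few compounds, and the source may have more. Where it says the series, first, only, none or still open, it means among the compounds named here.

- compound 1 (`O=C1/C(=C/c2cccnc2)CNC/C1=C\c1ccccc1F`) 21000 nM
- compound 2 (`O=C1/C(=C/c2cccnc2)CNC/C1=C\c1ccccc1C(F)(F)F`) 5020 nM

Both values come from a functional assay on HepG2 cells (Homo sapiens) for cytotoxicity, read by MTT assay, with a stated time of 24 h (on this read-out lower numbers stand for stronger inhibition and higher numbers for weaker inhibition), and, of the two numbers available, compound 2 holds the lower, at 5020 nM in this series. The next structure is compound 3 (`O=C1/C(=C/c2cccnc2)CN(S(=O)(=O)c2ccc(Br)cc2)C/C1=C\c1ccccc1C(F)(F)F`). The change is (4-bromophenyl)sulfonyl in place of hydrogen on an amine nitrogen in a ring and it amounts to (4-bromophenyl)sulfonyl in place of hydrogen on an amine nitrogen in a ring. Going by the values given here, the only measured step is a 4.2-fold lower number from compound 1 to compound 2 (0.62 log units; beyond the scatter) and it concerns trifluoromethyl in place of fluoro on an aromatic carbon. That modest step lies at a different place, so it offers a rough scale but no direction. Among the compounds with values here, neither measured compound carries anything but hydrogen on that nitrogen, and the data hold no direct precedent for this change. A step of similar size towards lower numbers is tentatively expected. The expected change is a 2.5-fold lower number from compound 2 to compound 3 (0.40 log units; beyond the scatter) in this assay and its direction remains uncertain. For compound 3 the estimated value is 2000 nM with an expected range from 500 nM to 8000 nM in this assay.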

Compound 3, half-maximal inhibitory concentration: 2730 nM
Compound 3: middle estimate off by 1.4-fold (0.14 log units), on the low side, and the stated range covers the measured number.
By their numbers in this assay, from the lowest: compounds 3 and 2 (each within the scatter of the next); then compound 1.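

Up to compound 2, the amine nitrogen in the ring carried only hydrogen, so nothing was known about substitution at this position. In this assay, the step is a 1.8-fold lower number from compound 2 to compound 3 (0.26 log units; within the scatter), which shows that this nitrogen can carry (4-bromophenyl)sulfonyl, a group with an aromatic ring of its own, without a reading beyond the scatter; on these numbers, compound 2 and compound 3 cannot be told apart. No measured information is available that could account for this result.

Two parts of the new group remain unseparated, the sulfonyl link and the 4-bromophenyl ring, so a plain phenylsulfonyl, a methylsulfonyl or an acetyl on the same nitrogen would be needed to show whether either part matters to the reading in this assay. Also open, as far as these compounds go, is whether the same substitution gives a similar step with fluoro in place of trifluoromethyl on the aromatic carbon, and whether a longer chain ending in an amine or a carboxylic acid on this nitrogen would move the number beyond the scatter.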